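Trifluoromethyl for Methyl on the Chlorophenyl Arm

This account rests on a few compounds, and the source may have more. Where it says the series, first, only, none or still open, it means among the compounds named here.

Three compounds have been measured in a functional assay on MCF7 cells (Homo sapiens) for inhibition; on this read-out higher numbers stand for weaker inhibition and lower numbers for stronger inhibition:
compound 1 `CC/C(=C(/c1ccc(/C=C/C(=O)O)cc1)c1cc2ccccc2[nH]1)c1ccccc1C#N` gives 9 nM;
compound 2 `CC/C(=C(/c1ccc(/C=C/C(=O)O)cc1)c1cc2ccccc2[nH]1)c1ccc(Cl)cc1` gives 343 nM;
compound 3 `CC/C(=C(/c1ccc(/C=C/C(=O)O)cc1)c1cc2ccccc2[nH]1)c1ccc(Cl)c(C)c1` gives 840 nM.

Compound 3 stands highest of the three in this assay. Its nearest neighbour is compound 2, separated by a 2.4-fold higher number from compound 2 to compound 3 (0.39 log units; beyond the scatter), and its furthest is compound 1, separated by a 93-fold higher number from compound 1 to compound 3 (1.97 log units; beyond the scatter); the remaining step is a 38-fold higher number from compound 1 to compound 2 (1.58 log units; beyond the scatter).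

Compound 4 `CC/C(=C(/c1ccc(/C=C/C(=O)O)cc1)c1cc2ccccc2[nH]1)c1ccc(Cl)c(C(F)(F)F)c1` differs from compound 3 in one place: trifluoromethyl in place of methyl on an aromatic carbon. Among the compounds with values here, no measured step replaces a methyl with a trifluoromethyl. Within the data shown here, the one step that concerns the same aromatic carbon is a 2.4-fold higher number from compound 2 to compound 3 (0.39 log units; beyond the scatter), which was modest and upward. The two large steps both involve the exchange of the whole aryl group rather than a single substituent on it, and they only show that this arm accounts for most of the spread among the measured compounds. On this basis compound 4 is expected to show a 1.4-fold higher number from compound 3 to compound 4 (0.15 log units; within the scatter). Compound 4 is therefore estimated at 1200 nM in this assay, within a range from 400 nM to 4000 nM.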

Compound 4, half-maximal inhibitory concentration: 2200 nM
Compound 4: middle estimate off by 1.8-fold (0.26 log units), on the low side, within the range that was stated.
By their numbers in this assay, from the lowest: compound 1; then compound 2; then compound 3; then compound 4.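

In this assay, this aromatic carbon, ortho to a chloro group, responds to which group it carries and not merely to whether it carries one: trifluoromethyl in place of methyl gives a 2.6-fold higher number from compound 3 to compound 4 (0.42 log units; beyond the scatter), and trifluoromethyl in place of hydrogen gives a 6.4-fold higher number from compound 2 to compound 4 (0.81 log units; beyond the scatter), so both groups seen at this carbon raise the number relative to hydrogen, and the larger rise belongs to trifluoromethyl. Substitution here moves the arm still further from the 2-cyanophenyl arm, with a 240-fold higher number from compound 1 to compound 4 (2.39 log units; beyond the scatter), so neither the methyl nor the trifluoromethyl group recovers any of the ground lost on leaving the 2-cyanophenyl arm. Nothing available here explains why the number rises with either group at this carbon.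

Going by these compounds, whether a methoxy group, an amine or a single fluorine on this carbon would also raise the number remains open, and so does whether any group here can lower it. Also open, on these data alone, is how a trifluoromethyl group would behave on the 2-cyanophenyl arm of compound 1, where the numbers are far lower.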